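Chain extension on the shared core, from compound 2 to compound 3

This account rests on a few compounds, and the source may have more. Where it says the series, first, only, none or still open, it means among the compounds named here.

Compound 1 `Clc1ccc2cc3c(cc2n1)C1CNCC3C1` and compound 2 `Cc1cnc2cc3c(cc2c1)C1CNCC3C1` sit on the same core. In an assay for binding affinity to Neuronal acetylcholine receptor; alpha4/beta2 (Rattus norvegicus) (on this read-out lower numbers stand for stronger inhibition and higher numbers for weaker inhibition), compound 1 gives 0.27 nM. In this assay compound 2 gives 0.65 nM, the higher of the two numbers, with the gap to compound 1 beyond the scatter. Compound 3 `CCc1cnc2cc3c(cc2c1)C1CNCC3C1` differs from compound 2 by methyl in place of hydrogen on a saturated chain carbon bound to an aromatic carbon. Among the measured compounds shown here, no measured pair shows this change, so in this assay only a small step is expected, toward a slightly higher number, possibly none beyond the scatter. The expected step is a 1.4-fold higher number from compound 2 to compound 3 (0.14 log units; within the scatter). For compound 3 the estimate in this assay is 0.9 nM, within 0.3 nM to 3 nM.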

Compound 3, inhibition constant: 1.2 nM
Compound 3: the middle estimate sits 1.3-fold (0.12 log units) below what was measured; low and high end bracket the measured number.
By their numbers in this assay, from the lowest: compound 1; then compounds 2 and 3 (each within the scatter of the next).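

Methyl to ethyl, on a saturated chain carbon bound to an aromatic carbon, is the first single-place change measured in this series. In this assay it gives a 1.8-fold higher number from compound 2 to compound 3 (0.27 log units; within the scatter), so this position accepts the added methyl without a step beyond the scatter. Nothing on hand explains the size of this step.

A single step sets no trend for this position. As far as these compounds go, whether a longer chain such as propyl, or an amine or a carboxylic acid at the same place, also stays within the scatter of compound 2 remains open.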